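Working notes: the step from compound 3 to compound 4

A few compounds are considered here, and "the series" means these few. Any claim that something is new, unique, unknown or untested is made for them only; others in the source may bear on it.

Measured in a physicochemical assay for lipophilicity, using the shake flask method, measured as octanol-water partition, at pH 7.4 (on this read-out higher numbers stand for higher lipophilicity and lower numbers for lower lipophilicity), so far:
- compound 1 `CC(=O)N[C@@H]1CCC[C@H](C(=O)Nc2cc(-c3nnn4ccccc34)c(Cl)cn2)C1` gives 2
- compound 2 `CC(=O)N[C@@H]1CCC[C@H](C(=O)Nc2cc(-c3cnn4c3CCCCC4)c(Cl)cn2)C1` gives 3.6
- compound 3 `CC(=O)N[C@@H]1CCC[C@H](C(=O)Nc2cc(-c3cnn4c3OCCC4)c(Cl)cn2)C1` gives 2.6

Compound 3 holds the middle place of these three numbers, above compound 1 and under compound 2. The change to compound 4 `CC(=O)N[C@@H]1CCC[C@H](C(=O)Nc2cc(-c3cnn4c3CC(C)(C)C4)c(Cl)cn2)C1` is a group of 10 heavy atoms (8 carbon, 2 nitrogen; one five-membered non-aromatic ring with 1 hetero atom, one five-membered aromatic ring with 2 hetero atoms) in place of a group of 9 heavy atoms (6 carbon, 2 nitrogen, 1 oxygen; one five-membered aromatic ring with 2 hetero atoms, one six-membered non-aromatic ring with 2 hetero atoms), on an aromatic carbon, and the entering group carries the same atom counts as the group in compound 2, though with different rings. The closest evidence is a number 1.00 log units lower from compound 2 to compound 3 (beyond the scatter), a modest step running against the direction now taken. Also relevant are a number 1.60 log units higher from compound 1 to compound 2 (beyond the scatter), which is large, and a number 0.60 log units higher from compound 1 to compound 3 (beyond the scatter), which is modest. Among the measured compounds shown here, no measured compound carries the five-membered non-aromatic ring, so only part of that downward step is expected to return. An upward step is expected in this assay, estimated as a number 0.70 log units higher from compound 3 to compound 4 (beyond the scatter) and modest in size. The estimate for compound 4 is 3.3, expected to fall within 2.9 to 3.7 on this read-out.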

Compound 4, distribution coefficient: 3.8
The estimate for compound 4 lay 0.50 log units below the measured number; measured number above the stated range.
By their numbers in this assay, from the lowest: compound 1; then compound 3; then compounds 2 and 4 (each within the scatter of the next).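

At this position, ortho to the chloro group, the five-membered non-aromatic ring group stands well clear of the oxygen-bearing group of compound 3 in this assay (a number 1.20 log units higher from compound 3 to compound 4 (beyond the scatter)). It does not separate from the seven-membered non-aromatic ring group (a number 0.20 log units higher from compound 2 to compound 4 (within the scatter)), though it remains far from the group of compound 1 (a number 1.80 log units higher from compound 1 to compound 4 (beyond the scatter)). Nothing measured accounts for these steps.

Going by these compounds, how the number responds to an amine or a carboxylic acid on this aromatic carbon remains open. Also open, on these data alone, is what an oxygen in the five-membered non-aromatic ring would give.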